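The source may hold more compounds than are shown below. What is called first, only, known or untested is meant among the compounds shown, and "the series" means these compounds.

Measured compounds:
- compound 1, `NC(=O)CCSC(SCCC(=O)O)c1cccc(/C=C/c2ccc3ccc(Cl)cc3n2)c1`: 0.3 nM
- compound 2, `CN(C)C(=O)CCSC(SCCC(=O)O)c1cccc(SCc2ccc3ccccc3n2)c1`: 89 nM

Of the two compounds measured in an assay on membranes from lung for binding affinity to cysteinyl leukotriene receptor 1 (Cavia porcellus) (on this read-out lower numbers stand for stronger inhibition and higher numbers for weaker inhibition), compound 1 gives the lower number, 0.3 nM, while compound 2 gives 89 nM, a gap well beyond the usual scatter of the assay. Compound 1 therefore stands as the stronger of the two on this read-out.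

Compound 3, `O=C(O)CCSC(SCCC(=O)N1CCOCC1)c1cccc(/C=C/c2ccc3ccc(Cl)cc3n2)c1`, has not yet been measured. It differs from compound 1 in one place: morpholin-4-yl in place of amino on a carbonyl carbon. The 2-carbamoylethyl arm of compound 1 thus becomes a 2-((morpholin-4-yl)carbonyl)ethyl arm, with one hydrogen-bond donor lost and one hydrogen-bond acceptor gained.

Among the measured compounds shown here, no measured pair shows this exact change, so the step cannot be read from the data. Compound 1 sits at a very low number, leaving little room for improvement, and a step of modest size toward a higher number is expected, though one within or only slightly beyond the scatter would not surprise. The expected change is a 2.7-fold higher number from compound 1 to compound 3 (0.43 log units; beyond the scatter).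

For compound 3 in this assay the estimate is 0.8 nM, with a range from 0.2 nM to 4 nM.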

Compound 3, half-maximal inhibitory concentration: 2.2 nM
For compound 3 the middle estimate is 2.8-fold (0.44 log units) below the measured one; measured number inside the range.
By their numbers in this assay, from the lowest: compound 1; then compound 3; then compound 2.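

In this assay, morpholin-4-yl in place of amino on a carbonyl carbon gives a 7.3-fold higher number from compound 1 to compound 3 (0.87 log units; beyond the scatter), a step of modest size that lies beyond the scatter. The position thus takes a six-membered non-aromatic ring and loses a hydrogen-bond donor, and compound 3 still gives 2.2 nM, so the change raises the number without taking it to the level of a weak binder on this read-out. Nothing at hand explains why the number rises with this change.

The compounds shown leave open whether the step belongs to the lost hydrogen-bond donor, to the ring or to the ring oxygen, a question that a piperidin-1-yl or a methylamino group on the same carbonyl carbon would address. They also leave open whether a longer chain between the sulfur and the (morpholin-4-yl)carbonyl group would move the number further, and whether the same change behaves alike on a core other than that of compound 1.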